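Amide nitrogen substituent: compound 2 to compound 3

The source may hold more compounds than are shown below. What is called first, only, known or untested is meant among the compounds shown, and "the series" means these compounds.

Measured compounds:
compound 1, `CN1CCC(NC(=O)c2cc(-c3ccc(NS(=O)(=O)c4cccc(Cl)c4Cl)cc3)nc3[nH]ncc23)C1`: 21 nM
compound 2, `CNC(=O)c1cc(-c2ccc(NS(=O)(=O)c3cccc(Cl)c3Cl)cc2)nc2[nH]ncc12`: 929 nM

Among the measured compounds shown here, in an assay for inhibition of serine/threonine-protein kinase Sgk1 (Homo sapiens), with stated times of 30 min and 60 min, in the presence of a further agent that is not named here (a higher number here means a weaker inhibitor, a lower number a stronger inhibitor), compound 2 gives 929 nM, the highest of the two numbers measured so far. Its nearest neighbour is compound 1, which gives 21 nM; the step between them is a 44-fold higher number from compound 1 to compound 2 (1.65 log units; beyond the scatter), a large change that follows from replacing the 1-methylpyrrolidin-3-yl group with a methyl on the amide-type nitrogen.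

Compound 3, `CCNC(=O)c1cc(-c2ccc(NS(=O)(=O)c3cccc(Cl)c3Cl)cc2)nc2[nH]ncc12`, has not yet been measured. It differs from compound 2 by methyl in place of hydrogen on a saturated chain carbon bound to an amide-type nitrogen; read one bond further out, this is methyl to ethyl, methylcarbamoyl to ethylcarbamoyl. For the measured compounds named here, the only measured step, a 44-fold higher number from compound 1 to compound 2 (1.65 log units; beyond the scatter), bears on the same amide-type nitrogen but involves a ring-bearing group and a far larger change in what is counted, so it gives only a loose guide. The present change adds a single carbon, and the step of a 1.3-fold lower number from compound 2 to compound 3 (0.12 log units; within the scatter) is expected to be small, most likely within the scatter, with a slight lean towards a lower number. Compound 3 is therefore estimated at 700 nM, with a range from 250 nM to 2000 nM.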

Compound 3, half-maximal inhibitory concentration: < 1920 nM
Compound 3 ended at the assay's limit; the forecaster's own chance of this, stated with the estimate: 3%; the middle value lies beyond the limit too.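

In this assay compound 3 gives < 1920 nM, which is a limit of the assay and not a number. The steps from compound 1 and compound 2 to compound 3 therefore cannot be read. The compounds shown leave open whether going from methylcarbamoyl to ethylcarbamoyl changes the reading at all, and where compound 3 stands relative to compound 1.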